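Double-bond geometry: compound 2 to compound 3

This account rests on a few compounds, and the source may have more. Where it says the series, first, only, none or still open, it means among the compounds named here.

In a functional assay on HT-29 cells (Homo sapiens) for cytotoxicity, read by sulforhodamine B assay, with a stated time of 72 h (on this read-out lower numbers stand for stronger inhibition and higher numbers for weaker inhibition), compound 2 `CCCCC/C=C\C[C@]1(O)C=CC(=O)/C1=C/C=C/CCCC(=O)OC` gives 4100 nM and compound 1 `CCCCC/C=C\C[C@]1(O)C=CC(=O)/C1=C/C=C\CCCC(=O)OC` gives 6000 nM, two values within the scatter of each other. Compound 3 `CCCCC/C=C\C[C@]1(O)C=CC(=O)/C1=C\C=C\CCCC(=O)OC` is a further isomer: the two compounds have the same atoms and bonds and differ only in configuration as drawn: 1 of 4 stereo elements differ; a double bond is drawn E in compound 2 and Z in compound 3. Within the data shown here, only one measured step bears on this, a 1.5-fold lower number from compound 1 to compound 2 (0.17 log units; within the scatter), and it concerns a different double bond, so it is a loose guide. With that small step as the basis, no change beyond the scatter is expected in this assay. The expected size is a 1.1-fold higher number from compound 2 to compound 3 (0.04 log units; within the scatter). Compound 3 is estimated at 4500 nM, with an expected range of 2000 nM to 10000 nM.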

Compound 3, half-maximal inhibitory concentration: 7900 nM
Compound 3: middle estimate off by 1.8-fold (0.24 log units), on the low side; low and high end bracket the measured number.
By their numbers in this assay, from the lowest: compounds 2, 1 and 3 (each within the scatter of the next).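

In this assay, the geometry of this second double bond also gives no change beyond the scatter: a 1.9-fold higher number from compound 2 to compound 3 (0.28 log units; within the scatter). The other new step, a 1.3-fold higher number from compound 1 to compound 3 (0.12 log units; within the scatter), changes both double bonds at once and also stays within the scatter. Across compound 1, compound 2 and compound 3, neither double bond alone nor the two together separates these isomers in this assay.

As far as these compounds go, whether a carboxylic acid or an amide in place of the methyl ester would move the number remains open. Also open, from the compounds shown here alone, is whether these isomers stay this close on other cell lines.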